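Trifluoromethoxy for methyl on an aryl ring of compound 2

A few compounds are considered here, and "the series" means these few. Any claim that something is new, unique, unknown or untested is made for them only; others in the source may bear on it.

Measured compounds:
- compound 1, `Cc1ccc2nc(-c3ccccc3N(C)C)[nH]c(=O)c2c1`: 21.1%
- compound 2, `Cc1cccc(-c2nc3cc(C)ccc3c(=O)[nH]2)c1`: 56.3%
- compound 3, `Cc1cccc(-c2nc3ccc(C)cc3c(=O)[nH]2)c1`: 12.7%

The three compounds were tested in an assay on isolated protein for inhibition of DNA topoisomerase 1 (Homo sapiens), with a stated time of 30 min, tested at 20 uM; a lower number here means a weaker effect, a higher number a stronger effect of the compound at the concentration tested. Compound 2 stands at the top of the three numbers, with 56.3%. Its nearest neighbour is compound 1, whose 21.1% lies beyond the scatter below it, and compound 3 lies furthest away, its 12.7% also beyond the scatter below compound 2. No pair among these three differs in one place only, so no single step between measured compounds is known.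

Compound 4, `Cc1ccc2c(=O)[nH]c(-c3cccc(OC(F)(F)F)c3)nc2c1`, is not yet measured in this assay. It differs from compound 2 in one place: trifluoromethoxy in place of methyl on an aromatic carbon. The change sits on an aromatic carbon of a six-membered aromatic ring of carbon only, and nothing in the measured set shows how this assay answers to such a swap. The step is therefore expected to be small to moderate and downward, with a real chance of no change beyond the scatter. Compound 4 is estimated at 40%, between 15% and 65%, which means an expected step of a number 16.3 percentage points lower from compound 2 to compound 4 (beyond the scatter).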

Compound 4, a percentage reported as inhibition, at one concentration (the size of the read-out at that concentration, not a potency): 0%
Estimate against measurement, compound 4: 40 percentage points above; measured number outside the range, below it.
By their numbers in this assay, from the lowest: compound 4; then compounds 3 and 1 (each within the scatter of the next); then compound 2.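

In this assay the replacement of methyl by trifluoromethoxy on an aromatic carbon, meta to a large group, gives a number 56.3 percentage points lower from compound 2 to compound 4 (beyond the scatter) and leaves compound 4 with 0% at the concentration tested. Among the compounds shown here, the earlier compounds offered no step in one place at all, and this pair is the first to show that the read-out of compound 2 is not indifferent to the group on this carbon: this single exchange is enough to remove it entirely. The exchange brings in more heavy atoms and a hydrogen-bond acceptor, but nothing measured here tells which feature of the entering group matters, and no available evidence bears on why the read-out is lost.

The pair leaves open whether the loss belongs to trifluoromethoxy in particular or would also follow from a smaller group on the same carbon, such as methoxy, a chlorine atom or plain hydrogen, or from an amine there. It also leaves open whether the same exchange would have as large an effect on the aryl ring of compound 3, whose methyl on the core sits elsewhere.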